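The source may hold more compounds than are shown below. What is called first, only, known or untested is meant among the compounds shown, and "the series" means these compounds.

Compound 1 `CCCn1c(=O)c2nc(-c3cnn(Cc4ccc(F)cc4F)c3)[nH]c2n(CCC)c1=O`: 700 nM in an in vitro assay on HEK293 cells for displacement of a labelled ligand from adenosine receptor A2b (Homo sapiens); on this read-out lower numbers stand for stronger inhibition and higher numbers for weaker inhibition.
Compound 2 `CCCn1c(=O)c2nc(-c3cnn(-c4ccccc4)c3C(F)(F)F)[nH]c2n(CCC)c1=O`: > 6600 nM in this assay.

For the measured compounds named here, compound 1 holds the only actual number in this assay. For compound 2 the entry is a limit of the assay, not a number (the limit of > 6600 nM in this assay, at which 1 of the 2 values shown sits). Going by the values given here, no pair of measured compounds differs in only one place, so no measured step is known.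

Compound 3 `CCCn1c(=O)c2nc(-c3cnn(Cc4ccccc4C(F)(F)F)c3)[nH]c2n(CCC)c1=O` differs from compound 1 by 2-(trifluoromethyl)phenyl in place of 2,4-difluorophenyl on a saturated chain carbon bound to an aromatic nitrogen. A step from compound 1 to compound 3 of a 1.1-fold higher number from compound 1 to compound 3 (0.06 log units; within the scatter) is expected, none beyond the scatter in either direction. Compound 3 is estimated at 800 nM, within a range of 300 nM to 2500 nM.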

Compound 3, inhibition constant: 37 nM
The estimate for compound 3 lay 22-fold (1.33 log units) above the measured number; the whole stated range lies above it.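

In this assay, the group on the saturated chain carbon bound to an aromatic nitrogen proves sensitive to its phenyl substituents: 2-(trifluoromethyl)phenyl in place of 2,4-difluorophenyl gives a 19-fold lower number from compound 1 to compound 3 (1.28 log units; beyond the scatter). Neither group carries a hydrogen-bond donor or acceptor, so the step arises without either entering. Nothing measured here accounts for the step. Going by these compounds, whether the gain comes from adding trifluoromethyl or from losing the two fluorines stays open. Also open, on these data alone, is how a chlorine or methoxy group on this phenyl, or a longer chain to it, would read.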